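Chloro Added Twice: Does the Small Step Repeat?

The compounds below may be only part of what the source reports. "The series", "measured", "known", "first", "only" and "open" are said of these compounds alone.

Compound 1 `O=c1cc(-c2ccccc2)oc2cc(OCCCN3CCN(c4ccccc4)CC3)ccc12` and compound 2 `O=c1cc(-c2ccc(Cl)cc2)oc2cc(OCCCN3CCN(c4ccccc4)CC3)ccc12` share one core and differ in a single place, (chloro in place of hydrogen on an aromatic carbon). In a functional assay for antagonist activity at Adrenergic receptor alpha-1 (Rattus norvegicus) (on this read-out lower numbers stand for tighter binding and higher numbers for weaker binding), compound 1 gives 6.65 nM and compound 2 gives 8.47 nM, so that change made a 1.3-fold higher number from compound 1 to compound 2 (0.11 log units; within the scatter), too small a shift to count as a real difference. Compound 3 `O=c1cc(-c2ccccc2)oc2cc(OCCCBr)ccc12` is built on another core; how its core differs from that of compound 1 is not broken down here. In this assay compound 3 gives 390 nM, the highest number of the three and clearly apart from both others. Compound 4 `O=c1cc(-c2ccc(Cl)cc2)oc2cc(OCCCBr)ccc12` has not yet been measured. It differs from compound 3 by chloro in place of hydrogen on an aromatic carbon, and the place of the change is described in exactly the same words as for the first pair, so it is the same change carried onto a second core. Because the earlier step was a 1.3-fold higher number from compound 1 to compound 2 (0.11 log units; within the scatter), the expected step here is similarly small, a 1.2-fold higher number from compound 3 to compound 4 (0.06 log units; within the scatter). On that basis compound 4 is estimated at 450 nM, most likely between 200 nM and 1000 nM in this assay.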

Compound 4, dissociation constant: 679 nM
For compound 4 the middle estimate is 1.5-fold (0.18 log units) below the measured one; measured number inside the range.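

In this assay, replacing phenyl with 4-chlorophenyl on the second core gives a 1.7-fold higher number from compound 3 to compound 4 (0.24 log units; within the scatter), so here too the change makes no real difference to the number. The step therefore carries over from the core of compound 1 to the core of compound 3, and the two steps agree with each other: the same change on two cores in this assay, a 1.3-fold higher number (0.11 log units; within the scatter) from compound 1 to compound 2 and a 1.7-fold higher number (0.24 log units; within the scatter) from compound 3 to compound 4, 1.4-fold (0.14 log units) apart, within the scatter of two such steps. Within the data shown here, this rests on only two pairs, however, and since neither step stands clear of the scatter, it does not show that chloro truly moves the number in either direction, nor does it explain why the step stays small or predict what would happen on any further core.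

The compounds shown leave open whether a different group in that same place, such as methoxy, trifluoromethyl or an amine, would also leave the number essentially unchanged. They also leave open whether the chloro step stays this small on a related core with a longer chain.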